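Moving the Chlorine on the Aryl Group of Compound 1

The source may hold more compounds than are shown below. What is called first, only, known or untested is meant among the compounds shown, and "the series" means these compounds.

Compound 1 `Cn1c(-c2cccc(Cl)c2)nc2c(NC3CCCC3)ncnc21` was tested in an assay on CHO cells for displacement of a labelled ligand from adenosine receptor A1 (Homo sapiens), read by scintillation counting, with a stated time of 3 h (on this read-out lower numbers stand for stronger inhibition and higher numbers for weaker inhibition), where compound 1 gives 6.5 nM, the second highest of the three numbers shown. Compound 3 `Cn1c(-c2ccccc2)nc2c(NC3CCC3)ncnc21` gives 3.2 nM in this assay, and compound 2 `CCCn1c(-c2ccccc2)nc2c(NC3CCC3)ncnc21` gives 15 nM. Within the data shown here, the only step between single-point neighbours, a 4.7-fold lower number from compound 2 to compound 3 (0.67 log units; beyond the scatter), concerns the group on the aromatic nitrogen and says nothing about the chlorophenyl group. Compound 4 `Cn1c(-c2ccc(Cl)cc2)nc2c(NC3CCCC3)ncnc21` differs from compound 1 by 4-chlorophenyl in place of 3-chlorophenyl on an aromatic carbon. Among the measured compounds shown here, no measured pair isolates this change; compound 1 and compound 3 differ in two places, so their gap cannot be assigned to the chlorine position. A step within the scatter is therefore expected, a 1.2-fold higher number from compound 1 to compound 4 (0.09 log units; within the scatter). Compound 4 is estimated at 8 nM, between 2.5 nM and 25 nM.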

Compound 4, inhibition constant: 18 nM
Compound 4: middle estimate off by 2.3-fold (0.35 log units), on the low side; low and high end bracket the measured number.
By their numbers in this assay, from the lowest: compound 3; then compound 1; then compounds 2 and 4 (each within the scatter of the next).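

In this assay, the position of the chlorine on the aryl group makes a readable difference: 4-chlorophenyl in place of 3-chlorophenyl gives a 2.8-fold higher number from compound 1 to compound 4 (0.44 log units; beyond the scatter), beyond the scatter. The earlier compounds shown here offered no pair that isolated this change, and here the two groups have the same atoms, joined differently. Nothing shown here explains the difference.

Still open, on these data alone, is whether a methoxy group or an amine in place of the chlorine would read nearer compound 1 or compound 4. Also open, as far as these compounds go, is whether this step recurs with the longer chain of compound 2 on the aromatic nitrogen.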